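The compounds below may be only part of what the source reports. "The series", "measured", "known", "first", "only" and "open" are said of these compounds alone.

Measured compounds:
- compound 1, `Fc1ccccc1Cn1nc(-c2ccco2)c2cccnc21`; in a functional assay (aorta) with Oryctolagus cuniculus as the target (a higher number here means a weaker inhibitor, a lower number a stronger inhibitor), compound 1 gives 9300 nM
- compound 2, `Fc1ccccc1Cn1nc(-c2nn[nH]n2)c2cccnc21`; compound 2 gives 8600 nM
- compound 3, `CC(C)(C)c1cnc(-c2nn(Cc3ccccc3F)c3ncccc23)nc1N`; compound 3 gives 709000 nM

Compound 3 stands at the highest number of the three, and its gap to each of the other two is beyond the scatter, so it is the weakest inhibitor among the measured compounds. Compound 1 and compound 2 differ from each other by a 1.1-fold lower number from compound 1 to compound 2 (0.03 log units; within the scatter), a step that changes a ring substituent on a scaffold without the aminopyrimidine portion found in compound 3.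

Compound 4, `N#CCCCCCc1cnc(-c2nn(Cc3ccccc3F)c3ncccc23)nc1N`, has not yet been measured in this assay. It arises from compound 3 through (5-cyanopentyl in place of tert-butyl on an aromatic carbon). Among the compounds with values here, no measured step touches this kind of change: the one available step concerns a different pair and a different position, and it lay within the scatter. Within the data shown here, there is thus no precedent for exchanging tert-butyl for 5-cyanopentyl on the shared core, and the expectation must rest on compound 3 alone.

Compound 4 is therefore expected to remain near compound 3, with an estimated value of about 400000 nM and a range from 80000 nM to 2000000 nM. The step this estimate implies is a 1.8-fold lower number from compound 3 to compound 4 (0.25 log units; within the scatter), which is not expected to exceed the scatter with any confidence.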

Compound 4, half-maximal inhibitory concentration: 588000 nM
For compound 4 the middle estimate is 1.5-fold (0.17 log units) below the measured one; low and high end bracket the measured number.
By their numbers in this assay, from the lowest: compounds 2 and 1 (each within the scatter of the next); then compounds 4 and 3 (each within the scatter of the next).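

In this assay, within the data shown here, putting 5-cyanopentyl in place of tert-butyl on the aromatic carbon ortho to the amino group gives a 1.2-fold lower number from compound 3 to compound 4 (0.08 log units; within the scatter), and this pair is the first reading of that position. The change replaces a group of 4 heavy atoms with no hydrogen-bond acceptor by a chain of 7 heavy atoms ending in a nitrile, with 1 hydrogen-bond acceptor, yet the two compounds cannot be told apart in this read-out, so neither the added length nor the nitrile registers in this pair. No supporting measurement bears on why these two groups read alike.

From the compounds shown here alone, only these two groups have been seen at this position, so it remains open whether an amine, a carboxylic acid or a shorter chain ending in a nitrile there would move the number beyond the scatter. The compounds shown also leave open whether any group at this position could bring compound 3 close to the level of compound 1, which gives 9300 nM.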